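The compounds below may be only part of what the source reports. "The series", "measured", "known", "first", "only" and "open" are said of these compounds alone.

Compound 1 `C=CCCSC[C@H](NC(=O)c1cc(O)c(O)c(O)c1)C(=O)OC` gave 57800 nM.
Compound 2 `C=CCCCSC[C@H](NC(=O)c1cc(O)c(O)c(O)c1)C(=O)OC` gave 39200 nM.
Compound 3 `C=CCCSC[C@H](NC(=O)c1cc(O)cc(O)c1)C(=O)OC` gave 35800 nM.

All three compounds were measured in an assay on RAW264.7 cells for antagonist activity at Toll-like receptor 2 (Mus musculus), read by Griess assay, with a stated time of 24 h; on this read-out lower numbers stand for stronger inhibition and higher numbers for weaker inhibition. Compound 2 differs from compound 1 by a single change, (allyl in place of vinyl on a saturated chain carbon, two bonds along the chain from a sulfur), and that change produced a 1.5-fold lower number from compound 1 to compound 2 (0.17 log units; within the scatter). Compound 3 differs from compound 1 in its core: hydrogen in place of hydroxy on an aromatic carbon. That difference produced a 1.6-fold lower number from compound 1 to compound 3 (0.21 log units; within the scatter). Between compound 2 and compound 3 no step is worked out here; their two values lie close to each other, so nothing can be said about any order between them.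

Compound 4 `C=CCCCSC[C@H](NC(=O)c1cc(O)cc(O)c1)C(=O)OC` has not yet been measured in this assay. It differs from compound 3 by allyl in place of vinyl on a saturated chain carbon, two bonds along the chain from a sulfur. This is the same change that separates compound 1 from compound 2, now made on the core of compound 3. Because the earlier example of this change gave a 1.5-fold lower number from compound 1 to compound 2 (0.17 log units; within the scatter), the expected step is a 1.4-fold lower number from compound 3 to compound 4 (0.14 log units; within the scatter), a move too small to count as a real difference. Compound 4 is therefore estimated to give about 26000 nM in this assay. For compound 4 the expected range runs from 12000 nM to 60000 nM.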

Compound 4, half-maximal inhibitory concentration: 57800 nM
Estimate against measurement, compound 4: 2.2-fold (0.35 log units) below; measured number inside the range.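

In this assay, going from but-3-en-1-yl to pent-4-en-1-yl on the core of compound 3 gave a 1.6-fold higher number from compound 3 to compound 4 (0.21 log units; within the scatter), and hydrogen in place of hydroxy on an aromatic carbon, on the pent-4-en-1-yl side of the series, gave a 1.5-fold higher number from compound 2 to compound 4 (0.17 log units; within the scatter). The printed steps for the chain change point in opposite directions, yet the gap between them cannot be told apart from the ordinary spread of repeated measurements: the same change on two cores in this assay, a 1.5-fold lower number (0.17 log units; within the scatter) from compound 1 to compound 2 and a 1.6-fold higher number (0.21 log units; within the scatter) from compound 3 to compound 4, 2.4-fold (0.38 log units) apart, within the scatter of two such steps. The same holds for the swap of hydroxy for hydrogen, so these four compounds show neither that either change has a real effect on one of these cores nor that its effect depends on the core: the same change on two cores in this assay, a 1.6-fold lower number (0.21 log units; within the scatter) from compound 1 to compound 3 and a 1.5-fold higher number (0.17 log units; within the scatter) from compound 2 to compound 4, 2.4-fold (0.38 log units) apart, within the scatter of two such steps.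

Going by these compounds, what stays open is whether any edit can give a step beyond the scatter at all. A chain longer than pent-4-en-1-yl, an amine or a carboxylic acid could each test that, and the compounds shown say nothing about how such groups would read out.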